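Iodo in place of bromo: a small step expected

A few compounds are considered here, and "the series" means these few. Any claim that something is new, unique, unknown or untested is made for them only; others in the source may bear on it.

Measured so far in a functional assay on K562 cells (Homo sapiens) for inhibition, read by MTT assay, with a stated time of 48 h; a higher number here means a weaker inhibitor, a lower number a stronger inhibitor 
- Compound 1 `O=C(CCCCCC(=O)NCc1ccc2cc(Cl)ccc2n1)NO` at 3390 nM 
- Compound 2 `O=C(CCCCCC(=O)NCc1ccc2cc(Br)ccc2n1)NO` at 4860 nM 

Compound 2 stands at 4860 nM and so lies within the scatter of compound 1. Compound 3 `O=C(CCCCCC(=O)NCc1ccc2cc(I)ccc2n1)NO` has not yet been measured. It carries iodo in place of bromo on an aromatic carbon of a six-membered aromatic ring of carbon only, a change counted as iodo in place of bromo on an aromatic carbon and confined to that one group. Within the data shown here, one measured step bears on this, bromo in place of chloro at the same place, which gave a 1.4-fold higher number from compound 1 to compound 2 (0.16 log units; within the scatter) and stayed within the scatter. Among the measured compounds shown here, a single step is thin evidence, and no iodo compound has a value yet. Even so, no shift beyond the scatter is expected in this assay here. The expected step is a 1.0-fold higher number from compound 2 to compound 3 (0.01 log units; within the scatter) and it remains an estimate. For compound 3 the estimated value is 5000 nM with an expected range from 2400 nM to 10000 nM.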

Compound 3, half-maximal inhibitory concentration: 2450 nM
Beside the measured number, compound 3's estimate is 2.0-fold (0.31 log units) above it, within the range that was stated.
By their numbers in this assay, from the lowest: compounds 3, 1 and 2 (each within the scatter of the next).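

In this assay iodo in place of bromo gives a 2.0-fold lower number from compound 2 to compound 3 (0.30 log units; within the scatter) and iodo in place of chloro gives a 1.4-fold lower number from compound 1 to compound 3 (0.14 log units; within the scatter) so that chloro, bromo and iodo can now be compared at this one aromatic carbon. The earlier compounds shown here offered a single exchange of halogens, whereas these three offer every pairing, and none of the pairs falls outside the scatter, so no order among the halogens can be read at this position. Nothing available bears on why these exchanges give the numbers they do.

The compounds shown leave open whether a group other than a halogen on this aromatic carbon, such as an amine or a methoxy group, would give a step beyond the scatter. Among these compounds, they also leave open whether a longer chain in place of the one shared by compound 1, compound 2 and compound 3 would do so.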